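Aryl swap on the saturated ring carbon: compound 2 to 4

The source may hold more compounds than are shown below. What is called first, only, known or untested is meant among the compounds shown, and "the series" means these compounds.

Measured so far:
compound 1 `COC(=O)C1=C(C)N=C(C)/C(=C(/O)OC)C1c1c(F)cccc1Cl` gives 7.59 nM
compound 2 `COC(=O)C1=C(C)N=C(C)/C(=C(\O)OC)C1c1cccc(Cl)c1Cl` gives 19.1 nM
compound 3 `COC(=O)C1=C(C)N=C(C)/C(=C(/O)OC)C1c1cccc(Cl)c1` gives 15.9 nM

In a functional assay (muscle tissue) with Cavia porcellus as the target (on this read-out higher numbers stand for an effect only at larger amounts of compound and lower numbers for an effect already at smaller amounts), compound 2 gives 19.1 nM. That figure lies within the scatter of compound 3, which gives 15.9 nM. It lies beyond the scatter from compound 1, which gives 7.59 nM; of the three numbers, only the gap between compound 2 and compound 1 is a real difference.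

Compound 4 `COC(=O)C1=C(C)N=C(C)/C(=C(\O)OC)C1c1cc(C)ccc1C` differs from compound 2 in one place: 2,5-dimethylphenyl in place of 2,3-dichlorophenyl on a saturated ring carbon. For the measured compounds named here, the only measured step that touches the aryl group on this saturated ring carbon is a 2.1-fold higher number from compound 1 to compound 3 (0.32 log units; beyond the scatter), an exchange of one chlorinated phenyl for another. Going by the values given here, no measured step puts a phenyl carrying methyl groups, and no chlorine, on that carbon, so the data give only the rough size of an aryl swap, not its direction for this particular pair. Taking the 2,3-dichlorophenyl to 2,5-dimethylphenyl change as a step of similar size, and leaning toward a higher number because a 2.1-fold higher number from compound 1 to compound 3 (0.32 log units; beyond the scatter) went up in the nearest comparison, the expected step is a 1.7-fold higher number from compound 2 to compound 4 (0.22 log units; within the scatter). Compound 4 is therefore estimated at 32 nM, with a range from 11 nM to 95 nM.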

Compound 4, half-maximal effective concentration: 100 nM
Estimate against measurement, compound 4: 3.1-fold (0.49 log units) below; measured number outside the range, above it.
By their numbers in this assay, from the lowest: compound 1; then compounds 3 and 2 (each within the scatter of the next); then compound 4.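

In this assay, for the compounds shown here, 2,5-dimethylphenyl in place of 2,3-dichlorophenyl on the saturated ring carbon gives a 5.2-fold higher number from compound 2 to compound 4 (0.72 log units; beyond the scatter), while the only earlier aryl step on this carbon reads a 2.1-fold higher number from compound 1 to compound 3 (0.32 log units; beyond the scatter). Compound 4 is the only compound shown with methyl groups and no chlorine on this aryl ring, and its number is the highest of the four, so this position responds to more than the heavy-atom count: the two groups match in that count, in their six-membered aromatic ring of carbon only, in hydrogen-bond donors and acceptors and in net charge, and differ in their substituents and where these sit. Nothing at hand gives a reason for the size of this step.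

The compounds shown leave open whether the higher number follows from the exchange of chlorine for methyl or from the different placement on the ring, as the two change together in this one step. Also open, as far as these compounds go, is how this carbon responds to an aryl ring bearing something else, such as a methoxy group, an amine or a carboxylic acid, and whether 2,5-dichlorophenyl would read closer to compound 2 or to compound 4.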